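This account rests on a few compounds, and the source may have more. Where it says the series, first, only, none or still open, it means among the compounds named here.

Compound 1, `CCCSc1cc(C)c(C(=O)N=C(N)N)cc1S(C)(=O)=O`, gives 6.8 nM in a functional assay for inhibition of sodium/hydrogen exchanger (Oryctolagus cuniculus); a higher number here means a weaker inhibitor, a lower number a stronger inhibitor.
Compound 2, `COc1cc(Cl)c(C(=O)N=C(N)N)cc1S(C)(=O)=O`, gives 40 nM in this assay.
Compound 3, `CS(=O)(=O)c1cc(C(=O)N=C(N)N)c(Cl)cc1N1CCC(N)CC1`, gives 20 nM in this assay.

Among these three numbers compound 1 stands lowest; compound 3 is nearest to it and compound 2 furthest, and both gaps lie beyond the scatter. Compound 4, `Cc1cc(-n2ccnc2)c(S(C)(=O)=O)cc1C(=O)N=C(N)N`, has not yet been measured. It differs from compound 1 in one place: 1H-imidazol-1-yl in place of propylsulfanyl on an aromatic carbon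

Going by the values given here, only one measured step speaks to such a replacement of a small group by a nitrogen-linked ring on the same kind of carbon. That step is a 2.0-fold lower number from compound 2 to compound 3 (0.30 log units; within the scatter). Among the compounds with values here, a single step within the scatter gives little ground to expect a large move, and no other pair of measured compounds touches this position. For compound 4 the expectation is therefore a step of a 1.5-fold higher number from compound 1 to compound 4 (0.17 log units; within the scatter), which is to say no clear change beyond the scatter. The estimated value for compound 4 in this assay is 10 nM, with a range from 4 nM to 30 nM.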

Compound 4, half-maximal inhibitory concentration: 23 nM
Estimate against measurement, compound 4: 2.3-fold (0.36 log units) below; low and high end bracket the measured number.
By their numbers in this assay, from the lowest: compound 1; then compounds 3, 4 and 2 (each within the scatter of the next).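

In this assay, a 3.4-fold higher number from compound 1 to compound 4 (0.53 log units; beyond the scatter) shows that this aromatic carbon, ortho to a methylsulfonyl group, is sensitive to what it carries: with 1H-imidazol-1-yl in place of propylsulfanyl, compound 4 is a modestly weaker inhibitor. The earlier change to a nitrogen-linked ring, 4-aminopiperidin-1-yl in place of methoxy, was a 2.0-fold lower number from compound 2 to compound 3 (0.30 log units; within the scatter), so a nitrogen-linked ring does not leave the number unchanged in every case, although the two changes differ in both the group leaving and the group entering. No measurement is available that accounts for the step seen with compound 4.

As far as these compounds go, it remains open whether the step follows from removing the propylsulfanyl chain or from introducing the imidazole ring. A methylsulfanyl group, a phenyl ring or 4-aminopiperidin-1-yl on the same carbon of the core of compound 1 would help separate these two readings.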